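The source may hold more compounds than are shown below. What is called first, only, known or untested is meant among the compounds shown, and "the series" means these compounds.

Measured compounds:
Compound 1, `CCOC(=O)C1=Cc2ccccc2OC1(OCc1cc(-c2ccc(C)cc2)no1)C(F)(F)F`. In a functional assay on HeLa cells (Homo sapiens) for inhibition, read by MTT assay, with a stated time of 24 h (on this read-out higher numbers stand for weaker inhibition and lower numbers for stronger inhibition), compound 1 gives > 150000 nM, which is a limit of the assay and not a number.
Compound 2, `Cc1ccc(-c2cc(COC3(C(F)(F)F)Oc4ccccc4C=C3C(=O)O)on2)cc1`. In this assay compound 2 gives 33400 nM.

Within the data shown here, the one measured step, an at least 4.4-fold lower number from compound 1 to compound 2 (0.65 log units; beyond the scatter), concerns hydrogen in place of ethyl on an oxygen next to a carbonyl group. Among the measured compounds shown here, compound 2 therefore holds the only number in this assay; the other value shown sits at the limit of > 150000 nM in this assay, at which 1 of the 2 values shown sits.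

Compound 3, `O=C(O)C1=Cc2ccccc2OC1(OCc1cc(-c2ccc([N+](=O)[O-])cc2)no1)C(F)(F)F`, differs from compound 2 by nitro in place of methyl on an aromatic carbon. For the measured compounds named here, no measured step touches this part of the molecule: the step from compound 1 to compound 2 changed the ester side and leaves the aryl substituent untouched, so it gives no guide to the direction or size of a change on the aromatic ring. With nothing to point either way, the working expectation for compound 3 is a step of about none beyond the scatter, a 1.1-fold lower number from compound 2 to compound 3 (0.05 log units; within the scatter), with a wide range to either side. Compound 3 is thus estimated at 30000 nM in this assay, expected between 8000 nM and 120000 nM.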

Compound 3, half-maximal inhibitory concentration: > 150000 nM
Compound 3: only a limit was reported; the forecaster's own chance of this, stated with the estimate: 20%; middle value at least 5.0-fold (0.69 log units) away from the limit.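

In this assay the position para to a large group on the outer aromatic ring proves sensitive: moving from 4-methylphenyl to 4-nitrophenyl gives an at least 4.4-fold higher number from compound 2 to compound 3 (0.65 log units; beyond the scatter). The free carboxylic acid, the feature that separated compound 2 from compound 1, is therefore not enough on its own to keep a measurable number, since compound 3 carries it as well. For compound 3 the reading of > 150000 nM is a limit of the assay and not a number, so the step gives only a minimum size, and a change on either side of the molecule can now bring the series back to the same limit: the limit of > 150000 nM in this assay, at which 2 of the 3 values shown sit.

With only methyl and nitro shown at this position, the compounds cannot separate an effect of losing methyl from an effect of gaining nitro, and hydrogen, chloro or methoxy at the same place would help to tell these apart. Also open, from the compounds shown here alone, is whether the number of compound 2 can be improved at all from this starting point, for instance with a longer alkyl chain on the aromatic ring or with an amide in place of the carboxylic acid.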